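The compounds below may be only part of what the source reports. "The series", "measured", "known", "first", "only" and "open" are said of these compounds alone.

Of the compounds shown here, three sharing one core have been tested in a functional assay for antagonist activity at Neuropeptides B/W receptor type 1 (Homo sapiens), read by cAMP accumulation; on this read-out lower numbers stand for stronger inhibition and higher numbers for weaker inhibition. Compound 1 `O=[N+]([O-])c1ccc2nc(-c3ccc(Cl)cc3Cl)[nH]c2c1` gives 2880 nM in this assay. Compound 2 `O=[N+]([O-])c1ccc2[nH]c(-c3ccc(-c4ccccc4)cc3)nc2c1` gives 4880 nM, the highest of the three numbers, although its gap to compound 1 lies within the scatter of repeated measurements. Compound 3 `Cc1cc(-c2nc3cc([N+](=O)[O-])ccc3[nH]2)ccc1Cl` gives 2290 nM, a number lower than that of compound 2 by more than the scatter. Compound 4 `NS(=O)(=O)c1ccc(-c2nc3cc([N+](=O)[O-])ccc3[nH]2)cc1` has not yet been measured; it differs from compound 2 in one place: sulfamoyl in place of phenyl on an aromatic carbon. Within the data shown here, no measured pair shows this change, so its direction cannot be read from the data. The expected step is a 1.2-fold lower number from compound 2 to compound 4 (0.09 log units; within the scatter), one that need not exceed the scatter. The estimate for compound 4 is 4000 nM, between 1500 nM and 12000 nM.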

Compound 4, half-maximal inhibitory concentration: > 31600 nM
Compound 4 was reported as a limit; the forecaster's own chance of this, stated with the estimate: 15%; middle value at least 7.9-fold (0.89 log units) from the limit.
By their numbers in this assay, from the lowest: compounds 3, 1 and 2 (each within the scatter of the next, the first and the last beyond it). At a limit, above all of these: compound 4.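

Among these compounds, the earlier compounds offered no step in a single place; this is the first, and it shows that this position, on an aromatic carbon para to a large group, does not accept every group: sulfamoyl in place of phenyl gives an at least 6.4-fold higher number from compound 2 to compound 4 (0.81 log units; beyond the scatter). In this assay, on these data alone, compound 4 is recorded only as a limit, > 31600 nM, so the full size of the step stays unknown. Whether an amine or a carboxylic acid on this carbon would behave like sulfamoyl remains open, as does the cause of the change.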